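This account rests on a few compounds, and the source may have more. Where it says the series, first, only, none or still open, it means among the compounds named here.

Compound 1 `CN1CCN(CCCCCn2c3c(c4ccccc42)C(=O)c2c[n+]([O-])c4ccccc4c2C3=O)CC1` was tested in a functional assay on MDA-MB-231 cells (Homo sapiens) for cytotoxicity, read by MTT assay, with a stated time of 72 h (on this read-out lower numbers stand for stronger inhibition and higher numbers for weaker inhibition), where compound 1 gives 2270 nM, the highest of the three numbers recorded. Compound 2 `O=C1c2c[n+]([O-])c3ccccc3c2C(=O)c2c1c1ccccc1n2CCCCN1CCCCC1` gives 610 nM in this assay, and compound 3 `CN(C)CCCCCn1c2c(c3ccccc31)C(=O)c1c[n+]([O-])c3ccccc3c1C2=O` gives 240 nM. Compound 4 `O=C1c2c[n+]([O-])c3ccccc3c2C(=O)c2c1c1ccccc1n2CCN1CCCCC1` has not yet been measured; set against compound 1, the change is piperidin-1-yl in place of 3-(4-methylpiperazin-1-yl)propyl on a saturated chain carbon, two bonds along the chain from an aromatic nitrogen. Going by the values given here, two measured steps bear on this change, since both replace the 4-methylpiperazin-1-yl group of compound 1 with a smaller amine: a 3.7-fold lower number from compound 1 to compound 2 (0.57 log units; beyond the scatter), and a 9.5-fold lower number from compound 1 to compound 3 (0.98 log units; beyond the scatter). Between those two amines, a 2.5-fold lower number from compound 2 to compound 3 (0.41 log units; beyond the scatter). Among the compounds with values here, no measured pair speaks to the shortening of the chain itself, so that part of the change is untested, and the chain count differs from anything already seen. On the strength of the two steps away from compound 1, the expected step is a 3.2-fold lower number from compound 1 to compound 4 (0.51 log units; beyond the scatter), a lower number. Compound 4 is therefore estimated at 700 nM, within a range from 200 nM to 2500 nM.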

Compound 4, half-maximal inhibitory concentration: 1050 nM
For compound 4 the middle estimate is 1.5-fold (0.18 log units) below the measured one, within the range that was stated.
By their numbers in this assay, from the lowest: compound 3; then compounds 2 and 4 (each within the scatter of the next); then compound 1.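

In this assay, going by these compounds alone, the 2-(piperidin-1-yl)ethyl chain of compound 4 still improves on the 5-(4-methylpiperazin-1-yl)pentyl chain of compound 1, with a 2.2-fold lower number from compound 1 to compound 4 (0.33 log units; beyond the scatter), while the first comparison of chain length with the piperidin-1-yl group held constant gives a 1.7-fold higher number from compound 2 to compound 4 (0.24 log units; within the scatter). Compound 3 remains apart, with a 4.4-fold higher number from compound 3 to compound 4 (0.64 log units; beyond the scatter), a step that changes both the amine and the chain length. Nothing available accounts for these differences.

The compounds shown leave open whether chain length matters for dimethylamino or 4-methylpiperazin-1-yl, as each appears here on a single chain length. They also leave open how a morpholine ring or a chain longer than a pentyl chain would read in this assay.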